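From cyclooctylamino to pyrrolidin-1-yl on a carbonyl carbon

The source may report more compounds than this note shows. Statements on the series, on what has been measured and on what is new or still open speak of the compounds shown alone.

Measured in a functional assay on MIA PaCa-2 cells (Homo sapiens) for cytotoxicity, read by fluorescence, with a stated time of 48 h; a higher number here means that more compound is needed for the effect, a lower number that less compound is needed:
- compound 1 `CC(C)=CCC/C(C)=C/CC/C(C)=C/CSC[C@H](NC(=O)CCCCCN1CCCC1)C(=O)NC1CCCCC1`: 5600 nM
- compound 2 `CC(C)=CCC/C(C)=C/CC/C(C)=C/CSC[C@H](NC(=O)CCCCCN1CCCC1)C(=O)N1CCCCC1`: 12400 nM
- compound 3 `CC(C)=CCC/C(C)=C/CC/C(C)=C/CSC[C@H](NC(=O)CCCCCN1CCCC1)C(=O)NC1CCCCCCC1`: 1900 nM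

Of these three, compound 3 gives the lowest number, 1900 nM, so it needs the least compound for the effect. Its steps to both of the others lie beyond the scatter.

The next compound, compound 4 `CC(C)=CCC/C(C)=C/CC/C(C)=C/CSC[C@H](NC(=O)CCCCCN1CCCC1)C(=O)N1CCCC1`, has one change from compound 3: pyrrolidin-1-yl in place of cyclooctylamino on a carbonyl carbon.

Among the compounds with values here, three measured steps bear on this. The closest is a 6.5-fold lower number from compound 2 to compound 3 (0.81 log units; beyond the scatter), where cyclooctylamino replaces piperidin-1-yl, and the change to compound 4 runs the opposite way. The step of a 2.2-fold higher number from compound 1 to compound 2 (0.35 log units; beyond the scatter) also points upward when piperidin-1-yl replaces cyclohexylamino. The step of a 2.9-fold lower number from compound 1 to compound 3 (0.47 log units; beyond the scatter) shows that the number also moves with ring size among the amino groups. Within the data shown here, none of the three compounds goes against this trend, but no measured compound carries pyrrolidin-1-yl, so the effect of the smaller ring is unknown.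

Compound 2, the nearest relative, gives 12400 nM, and the expectation rests on that value. The estimated change in this assay is therefore a clear rise, a 7.4-fold higher number from compound 3 to compound 4 (0.87 log units; beyond the scatter). Compound 4 is expected at 14000 nM, with an estimated range of 7000 nM to 30000 nM.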

Compound 4, half-maximal effective concentration: 10800 nM
The estimate for compound 4 lay 1.3-fold (0.11 log units) above the measured number, within the range that was stated.
By their numbers in this assay, from the lowest: compound 3; then compounds 1, 4 and 2 (each within the scatter of the next, the first and the last beyond it).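

In this assay, the step of a 5.7-fold higher number from compound 3 to compound 4 (0.75 log units; beyond the scatter) shows that on this carbonyl carbon, exchanging cyclooctylamino for pyrrolidin-1-yl costs a clear part of the effect, so more compound is needed. The step of a 1.1-fold lower number from compound 2 to compound 4 (0.06 log units; within the scatter) stays within the scatter, so the five-membered ring on nitrogen cannot be told apart from the piperidin-1-yl ring in this assay. The step of a 1.9-fold higher number from compound 1 to compound 4 (0.29 log units; within the scatter) is also within the scatter, so pyrrolidin-1-yl cannot be told apart from cyclohexylamino either, even though it lacks the amide hydrogen, and of the three other groups only cyclooctylamino stands clearly apart from it.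

No measurement among the data shown accounts for these differences. Still open, as far as these compounds go, is whether cyclooctylamino stands apart through its eight-membered carbon ring or through the amide hydrogen it carries, a question that azocan-1-yl, an eight-membered ring joined through its own nitrogen and with no amide hydrogen, could help to settle when compared with compound 3.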